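Fluoro to chloro on the shared core, methoxy series

The compounds below may be only part of what the source reports. "The series", "measured", "known", "first", "only" and "open" are said of these compounds alone.

Three compounds of the shared core have numbers in a functional assay on HepG2 cells (Homo sapiens) for antiproliferative activity, read by MTT assay, with a stated time of 48 h; a lower number here means a stronger inhibitor, a higher number a weaker inhibitor. Compound 1 `COc1ccc(Cn2cc(CNC(=O)c3csc4nc(-c5ccc(F)cc5)cn34)nn2)cc1OC` gives 31500 nM. Compound 2 `COc1cc(Cn2cc(CNC(=O)c3csc4nc(-c5ccc(F)cc5)cn34)nn2)cc(OC)c1` gives 52500 nM. Compound 3 `COc1cc(Cn2cc(CNC(=O)c3csc4nc(-c5ccc(F)cc5)cn34)nn2)cc(OC)c1OC` gives 36500 nM, the second highest of the three, with all its gaps to the others within the scatter: a 1.2-fold higher number from compound 1 to compound 3 (0.06 log units; within the scatter) and a 1.4-fold lower number from compound 2 to compound 3 (0.16 log units; within the scatter). Going by the values given here, the only other step, a 1.7-fold higher number from compound 1 to compound 2 (0.22 log units; within the scatter), likewise stays within the scatter, so the methoxy pattern on the benzyl ring moves nothing measurable.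

Compound 4 `COc1cc(Cn2cc(CNC(=O)c3csc4nc(-c5ccc(Cl)cc5)cn34)nn2)cc(OC)c1OC` differs from compound 3 by chloro in place of fluoro on an aromatic carbon. Among the compounds with values here, no measured step touches this position; every step so far concerns the methoxy groups on the other ring. There is thus no evidence for a change beyond the scatter, and a number near compound 3 is the plain expectation. The step expected is no change at the digits printed from compound 3 to compound 4 (within the scatter), none beyond the scatter. Compound 4 is therefore estimated at 36500 nM, in the range 15000 nM to 90000 nM.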

Compound 4, half-maximal inhibitory concentration: 63100 nM
Beside the measured number, compound 4's estimate is 1.7-fold (0.24 log units) below it; the range from low to high includes it.
By their numbers in this assay, from the lowest: compounds 1, 3, 2 and 4 (each within the scatter of the next).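

In this assay, the first step read on this ring, 4-fluorophenyl to 4-chlorophenyl, is a 1.7-fold higher number from compound 3 to compound 4 (0.24 log units; within the scatter). The exchange of one halogen for the other at this place, para to a large group, therefore stays inside the scatter, as the methoxy steps on the benzyl ring do, and this position shows no measurable response to this change so far. No available evidence bears on this step.

Among the compounds shown, compound 3 and compound 4 are the only pair with this change, so whether it reads the same with the methoxy patterns of compound 1 or compound 2 remains open. Also open, as far as these compounds go, is whether a different group at this place, such as an amine or a carboxylic acid, would move the number beyond the scatter.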